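The source may hold more compounds than are shown below. What is called first, only, known or untested is meant among the compounds shown, and "the series" means these compounds.

The compounds in this set were tested in an ADME assay on Vero cells (Chlorocebus sabaeus) for cytotoxicity, read by MTT assay, with a stated time of 72 h (on this read-out higher numbers stand for lower toxicity in this test and lower numbers for higher toxicity in this test), and only a few results exist. Within the data shown here, compound 2 `O=C(NNC(=O)c1ccncc1)C(=O)Nc1ccc(Cl)cc1O` gives 1170000 nM in this assay, and it stands as the only plain number among the values shown. One further entry is not a plain number and one has no result at all. Compound 3 `O=C1Oc2ccccc2N/C1=C\C(=O)c1ccc(-c2ccccc2)cc1` in this assay reaches only a limit of the measurement, > 366000 nM, which is the limit of > 366000 nM in this assay, at which 1 of the 3 values shown sits. Compound 1 `COC(=O)/C=C1\Nc2ncccc2OC1=O` has no result in this assay, "not determined" (no result reported).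

The step followed here leads from compound 2 to compound 4 `O=C(NNC(=O)c1ccncc1)C(=O)Nc1ccccc1O`. The difference between the two structures is hydrogen in place of chloro on an aromatic carbon. Among the measured compounds shown here, no step between two measured compounds exists in this set, so there is nothing measured to set the size of the change against. With so little to go on, the change in this assay is expected to be small, in no particular direction, and not beyond the usual scatter of repeated measurements. The expected step from compound 2 to compound 4 is a 1.0-fold higher number from compound 2 to compound 4 (0.01 log units; within the scatter). Compound 4 is therefore estimated to give about 1200000 nM in this assay, expected to lie between 450000 nM and 3000000 nM.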

Compound 4, half-maximal cytotoxic concentration: 1410000 nM
The estimate for compound 4 lay 1.2-fold (0.07 log units) below the measured number; the measured number falls inside the stated range.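

Among these compounds, the pair gives the first measured step of this set in this assay: a 1.2-fold higher number from compound 2 to compound 4 (0.08 log units; within the scatter). At this place on the ring, meta to a hydroxy group and para to a large group, the read-out therefore does not tell chloro and hydrogen apart, and taking away this one chlorine atom leaves compound 4 level with compound 2 within the usual scatter of the test. Nothing at hand bears on why the exchange reads this way.

The compounds shown carry only chloro or hydrogen at this place, so what an amine, a carboxylic acid or a longer chain there would do in this assay stays open. Among the compounds shown here, equally open is what a methoxy group in place of the hydroxy group on the same ring would do, and whether the exchange of chloro for hydrogen would read the same way on a core other than the one shared by compound 2 and compound 4.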